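The source may report more compounds than this note shows. Statements on the series, on what has been measured and on what is new or still open speak of the compounds shown alone.

In a functional assay on MCF7 cells (Homo sapiens) for cytotoxicity, read by MTT assay, with a stated time of 48 h (on this read-out higher numbers stand for weaker inhibition and lower numbers for stronger inhibition), three compounds sharing one core have been measured. Compound 1 `Cc1ccc(/C=C2/S/C(=N/c3ccccc3)N(Cc3ccncc3)C2=O)cc1` gives 36900 nM, compound 2 `CN(C)c1ccc(/C=C2/S/C(=N/c3ccccc3)N(Cc3ccncc3)C2=O)cc1` gives 76300 nM, and compound 3 `COc1ccc(/C=C2/S/C(=N/c3ccccc3)N(Cc3ccncc3)C2=O)cc1OC` gives 80700 nM. That puts compound 3 in the upper pair of numbers: a 1.1-fold higher number from compound 2 to compound 3 (0.02 log units; within the scatter) stays within the scatter, whereas a 2.2-fold higher number from compound 1 to compound 3 (0.34 log units; beyond the scatter) goes modestly beyond it.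

Compound 4 `Cc1ccc(/C=C2/S/C(=N/c3ccccc3)N(Cc3ccncc3)C2=O)s1` differs from compound 3 as follows: 5-methylthiophen-2-yl in place of 3,4-dimethoxyphenyl on a double-bonded chain carbon bound to a double-bonded ring carbon. In words, this is 5-methylthiophen-2-yl in place of 3,4-dimethoxyphenyl on a double-bonded chain carbon bound to a double-bonded ring carbon. The closest guide is a 2.2-fold higher number from compound 1 to compound 3 (0.34 log units; beyond the scatter), a change at the same place that introduced 3,4-dimethoxyphenyl in place of 4-methylphenyl. The other modest change, a 2.1-fold higher number from compound 1 to compound 2 (0.32 log units; beyond the scatter), also left a methyl-bearing aromatic group behind. Since compound 4 again carries a methyl on an aromatic ring, its number is expected to fall back towards that of compound 1, at 36900 nM. The expected change is a modest one towards stronger inhibition, a 2.1-fold lower number from compound 3 to compound 4 (0.33 log units; beyond the scatter). The estimated value for compound 4 is 38000 nM, with an expected range from 17000 nM to 85000 nM.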

Compound 4, half-maximal inhibitory concentration: 28700 nM
Estimate against measurement, compound 4: 1.3-fold (0.12 log units) above; the range from low to high includes it.
By their numbers in this assay, from the lowest: compounds 4 and 1 (each within the scatter of the next); then compounds 2 and 3 (each within the scatter of the next).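

In this assay, 5-methylthiophen-2-yl on a double-bonded chain carbon bound to a double-bonded ring carbon shows that a five-membered aromatic ring with a sulfur atom can stand in for 4-methylphenyl at this place, with a 1.3-fold lower number from compound 1 to compound 4 (0.11 log units; within the scatter). Replacing the other two groups counts for more, with a 2.8-fold lower number from compound 3 to compound 4 (0.45 log units; beyond the scatter) on losing 3,4-dimethoxyphenyl and a 2.7-fold lower number from compound 2 to compound 4 (0.42 log units; beyond the scatter) on losing 4-(dimethylamino)phenyl, so both groups that carry a methyl on an aromatic ring belong to the lower pair of numbers. Nothing measured here explains these steps.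

The compounds shown leave open whether the methyl or the ring matters more, a question that a plain phenyl or an unsubstituted thiophen-2-yl at this place would address. As far as these compounds go, how a chloro group or a carboxylic acid in place of that methyl would read also remains open.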